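Methylating the sulfonamide nitrogen of compound 3

The compounds below may be only part of what the source reports. "The series", "measured", "known", "first", "only" and "open" are said of these compounds alone.

Compound 1 `CN1C(=O)C(c2ccccc2Cl)N(C)c2nc(Nc3ccc(S(N)(=O)=O)cc3)ncc21` gives 129 nM in an assay on Sf9 cells for inhibition of serine/threonine-protein kinase 4 (Homo sapiens), read by luminescence and ADP-Glo, with a stated time of 1 h, in the presence of a further agent that is not named here; a higher number here means a weaker inhibitor, a lower number a stronger inhibitor. Compound 2 `CN1C(=O)C(c2ccccc2C(F)(F)F)N(C)c2nc(Nc3ccc(S(N)(=O)=O)cc3)ncc21` gives 56 nM. Compound 3 `CN1C(=O)C(c2c(F)cccc2F)N(C)c2nc(Nc3ccc(S(N)(=O)=O)cc3)ncc21` gives 42 nM.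

Compound 3 has the lowest of the three numbers, with compound 2 within the scatter (a 1.3-fold lower number from compound 2 to compound 3 (0.12 log units; within the scatter)) and compound 1 further away (a 3.1-fold lower number from compound 1 to compound 3 (0.49 log units; beyond the scatter)). Compound 4 `CNS(=O)(=O)c1ccc(Nc2ncc3c(n2)N(C)C(c2c(F)cccc2F)C(=O)N3C)cc1` differs from compound 3 by methyl in place of hydrogen on a sulfonamide nitrogen. The measured steps (a 2.3-fold lower number from compound 1 to compound 2 (0.36 log units; beyond the scatter), a 3.1-fold lower number from compound 1 to compound 3 (0.49 log units; beyond the scatter)) all concern the aryl group on the saturated ring carbon, and none touches the sulfonamide nitrogen, so nothing measured here bears directly on this change. In the absence of such a step, compound 4 is expected to stay near compound 3, with a 1.7-fold higher number from compound 3 to compound 4 (0.22 log units; within the scatter), the estimate being 70 nM with a range from 25 nM to 250 nM.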

Compound 4, half-maximal inhibitory concentration: 318 nM
Beside the measured number, compound 4's estimate is 4.5-fold (0.66 log units) below it; measured number above the stated range.
By their numbers in this assay, from the lowest: compounds 3 and 2 (each within the scatter of the next); then compound 1; then compound 4.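

On the sulfonamide nitrogen, even a single methyl in place of hydrogen counts: in this assay the change gives a 7.6-fold higher number from compound 3 to compound 4 (0.88 log units; beyond the scatter). Going by these compounds alone, this is the first measured change away from the aryl group on the saturated ring carbon, and it shows that the sulfonamide nitrogen does not tolerate every substitution. No evidence is available on what lies behind this step. The compounds shown leave open whether a longer chain, such as ethyl, or an acetyl group on this nitrogen would behave like methyl. They also leave open whether methyl has the same effect alongside the aryl groups of compound 1 and compound 2.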